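Hydrazone arm: 2-oxopropyl in place of hydroxyphenyl

The source may report more compounds than this note shows. Statements on the series, on what has been measured and on what is new or still open speak of the compounds shown alone.

Measured so far in a functional assay on the whole organism with Mus musculus as the target, in the maximal electroshock model, with a stated time of 0.5 h; on this read-out higher numbers stand for an effect only at larger amounts of compound and lower numbers for an effect already at smaller amounts:
compound 1 `C/C(=N\NC(=O)Nc1ccc(Br)cc1)c1ccc(O)cc1`: compound 1 gives 300 mg/kg
compound 2 `Cc1ccc(NC(=S)Nc2ccc(S(=O)(=O)Nc3ccc(Br)cc3)cc2)cc1`: compound 2 gives 100 mg/kg
compound 3 `CCOc1ccc(NC(=O)N/N=C(\C)c2ccc(O)cc2)cc1`: compound 3 gives 100 mg/kg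

Going by the values given here, compound 3 stands level with compound 2 at the digits recorded, the two together holding the lowest numbers of the three, and it is separated from compound 1 by a 3.0-fold lower number from compound 1 to compound 3 (0.48 log units; beyond the scatter), the only step measured. Compound 4 `CCOc1ccc(NC(=O)N/N=C(\C)CC(C)=O)cc1` differs from compound 3 by 2-oxopropyl in place of 4-hydroxyphenyl on a carbon with a double bond to nitrogen. Among the compounds with values here, no measured step touches this carbon: the single step, a 3.0-fold lower number from compound 1 to compound 3 (0.48 log units; beyond the scatter), concerns ethoxy in place of bromo on an aromatic carbon and carries no information about a 2-oxopropyl group. A step in this assay not beyond the scatter is therefore expected, with a lean toward a higher number. The estimate for compound 4 is 130 mg/kg, range 60 mg/kg to 300 mg/kg. This expected step is a 1.3-fold higher number from compound 3 to compound 4 (0.11 log units; within the scatter).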

Compound 4, minimum effective dose: 100 mg/kg
For compound 4 the middle estimate is 1.3-fold (0.11 log units) above the measured one; the range from low to high includes it.
By their numbers in this assay, from the lowest: compounds 2, 3 and 4 (each within the scatter of the next); then compound 1.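

In this assay, the carbon with a double bond to nitrogen accepts 2-oxopropyl in place of 4-hydroxyphenyl, with no change at the digits printed from compound 3 to compound 4 (within the scatter). The six-membered aromatic ring and the hydrogen-bond donor of 4-hydroxyphenyl are therefore not needed at this place for a reading at this level, at least with the ethoxy group on the other aryl ring. No available data bear on why the two groups read alike.

Going by these compounds, whether a simple methyl group or a longer chain at this carbon would read the same remains open. So does the part played by the carbonyl of 2-oxopropyl, which an amine or a carboxylic acid at that place could test.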